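This account rests on a few compounds, and the source may have more. Where it says the series, first, only, none or still open, it means among the compounds named here.

Working notes on the hydrazone-acylurea series.

Of the compounds shown here, three of the shared core have been measured in a functional assay on HepG2 cells (Homo sapiens) for inhibition, read by MTT assay, with a stated time of 72 h; on this read-out lower numbers stand for stronger inhibition and higher numbers for weaker inhibition. Compound 1 `CN(C(=O)NC(=O)c1ccc(Cl)cc1Cl)c1nc(C(F)(F)F)c(C(=O)N/N=C/c2ccc(C(F)(F)F)cc2)s1` gives 12.4 ug/mL. Compound 2 `CN(C(=O)NC(=O)c1cccc(C(F)(F)F)c1)c1nc(C(F)(F)F)c(C(=O)N/N=C/c2ccccc2C(F)(F)F)s1` gives 10.4 ug/mL. Compound 3 `CN(C(=O)NC(=O)c1c(F)cccc1F)c1nc(C(F)(F)F)c(C(=O)N/N=C/c2ccccc2C(F)(F)F)s1` gives 26.1 ug/mL, the highest number of the three; compound 1 sits a little below it and compound 2 lower still.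

For the measured compounds named here, the one single-point step recorded so far is a 2.5-fold higher number from compound 2 to compound 3 (0.40 log units; beyond the scatter), a modest rise.

Compound 4 `CN(C(=O)NC(=O)c1ccc(Cl)cc1Cl)c1nc(C(F)(F)F)c(C(=O)N/N=C/c2ccccc2C(F)(F)F)s1` differs from compound 3 in one place: 2,4-dichlorophenyl in place of 2,6-difluorophenyl on a carbonyl carbon. Going by the values given here, no measured step covers this exact exchange. Among the compounds with values here, what bears on it is that compound 1, which already carries the 2,4-dichlorophenyl on the carbonyl carbon, gives 12.4 ug/mL, a lower number than compound 3, and that the only step onto the 2,6-difluorophenyl, a 2.5-fold higher number from compound 2 to compound 3 (0.40 log units; beyond the scatter), raised the number. Moving back off that group is therefore expected to lower the number somewhat, on the order of the step seen, though the range must stay wide given two aryl groups change at once relative to compound 1.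

For compound 4 the expected step is a 2.0-fold lower number from compound 3 to compound 4 (0.30 log units; within the scatter). Compound 4 is estimated at 13 ug/mL, with a range of 6 ug/mL to 28 ug/mL.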

Compound 4, half-maximal inhibitory concentration: 10.7 ug/mL
Beside the measured number, compound 4's estimate is 1.2-fold (0.08 log units) above it; the range from low to high includes it.
By their numbers in this assay, from the lowest: compounds 2, 4 and 1 (each within the scatter of the next); then compound 3.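

In this assay the exchange on a carbonyl carbon gives a 2.4-fold lower number from compound 3 to compound 4 (0.39 log units; beyond the scatter) and so supplies a second step away from 2,6-difluorophenyl, of similar size to the one first seen in the other direction. With 2-(trifluoromethyl)phenyl held constant, a 1.0-fold higher number from compound 2 to compound 4 (0.01 log units; within the scatter) leaves 2,4-dichlorophenyl and 3-(trifluoromethyl)phenyl unresolved at this position, so among these three groups only 2,6-difluorophenyl stands apart. For the compounds shown here, the first reading on the other aryl group, a 1.2-fold lower number from compound 1 to compound 4 (0.06 log units; within the scatter) with 2,4-dichlorophenyl held constant, shows no resolved effect of exchanging 4-(trifluoromethyl)phenyl for 2-(trifluoromethyl)phenyl on a carbon with a double bond to nitrogen.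

As far as these compounds go, how the number responds when an amine, a carboxylic acid or a longer alkyl chain stands on the carbonyl carbon in place of a substituted phenyl remains open. The compounds shown offer no evidence that explains the higher number with 2,6-difluorophenyl.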